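Swapping Nitro for Bromo on a Shared Core

The compounds below may be only part of what the source reports. "The series", "measured", "known", "first", "only" and "open" are said of these compounds alone.

Compound 2 `N/C(=N/NC(CC(=O)c1ccc(-n2ccnc2)cc1)c1cccc([N+](=O)[O-])c1)c1ccccn1` gives 28700 nM in an ADME assay on Vero cells (Chlorocebus sabaeus) for cytotoxicity, read by MTT assay, with a stated time of 72 h (a lower number here means that less compound is tolerated, a higher number that more compound is tolerated), and stands alongside compound 1 `N/C(=N/NC(CC(=O)c1ccc(-n2ccnc2)cc1)c1cccc(F)c1)c1ccccn1`, which gives 26500 nM in this assay; the two differ only within the scatter. That single measured step, a 1.1-fold higher number from compound 1 to compound 2 (0.03 log units; within the scatter), changed one group on an aromatic carbon. Compound 3 `N/C(=N/NC(CC(=O)c1ccc(-n2ccnc2)cc1)c1cccc(Br)c1)c1ccccn1` changes the same place again: bromo in place of nitro on an aromatic carbon. Among the measured compounds shown here, only the step from compound 1 to compound 2 bears on this change, and it stayed within the scatter, so no step beyond the scatter is expected in this assay. Compound 3 is therefore estimated at 27000 nM, with a range from 13000 nM to 55000 nM, meaning an expected 1.1-fold lower number from compound 2 to compound 3 (0.03 log units; within the scatter).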

Compound 3, half-maximal cytotoxic concentration: 51300 nM
Compound 3: middle estimate off by 1.9-fold (0.28 log units), on the low side; low and high end bracket the measured number.
By their numbers in this assay, from the lowest: compounds 1, 2 and 3 (each within the scatter of the next).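

Bromo, as a third group at this place on the ring, still gives no step beyond the scatter in this assay: the new steps read a 1.8-fold higher number from compound 2 to compound 3 (0.25 log units; within the scatter) and a 1.9-fold higher number from compound 1 to compound 3 (0.29 log units; within the scatter) and so add to the earlier result. All three pairs among these compounds therefore stay within the scatter, even where a nitro of three heavy atoms gives way to a bromo of one. No measurement shown here accounts for these numbers. As far as these compounds go, whether an amine, a carboxylic acid or a longer chain at this place would also stay within the scatter remains open, as does the outcome of the same swaps elsewhere on the shared core.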